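The source may report more compounds than this note shows. Statements on the series, on what has been measured and on what is new or still open speak of the compounds shown alone.

Of the compounds shown here, three built on the same core have been tested in a functional assay on the whole organism (strain Swiss albino) for inhibition, with Mus musculus as the target, in the formalin test, with a stated time of 30 min, at a dose of 100 mg/kg; a higher number here means more inhibition at the dose given (going by the name of the read-out), a lower number less inhibition. Compound 1 `CCN1CCc2c(c(C)nn2C(=O)Nc2cc(C)ccc2C)C1` gives 55.8%. Compound 2 `CCN1CCc2c(c(C)nn2C(=O)Nc2cc(C)ccc2F)C1` gives 15%, and compound 3 `CCN1CCc2c(c(C(C)(C)C)nn2C(=O)Nc2cc(C)ccc2C)C1` gives 15.7%. Among the measured compounds shown here, of the three numbers, the one for compound 3 is the second highest, but it lies within the scatter of compound 2, so those two cannot be told apart, while compound 1 stands far above it: a number 40.1 percentage points lower from compound 1 to compound 3 (beyond the scatter). Compound 4 `CCN1CCc2c(c(C(C)(C)C)nn2C(=O)Nc2ccc(Cl)cc2)C1` has not yet been measured. It differs from compound 3 in one place: 4-chlorophenyl in place of 2,5-dimethylphenyl on an amide-type nitrogen. For the measured compounds named here, the only measured step on that same aryl group is a number 40.8 percentage points lower from compound 1 to compound 2 (beyond the scatter), where a single change on the ring cut inhibition sharply. Compound 4 alters that ring more thoroughly, with both methyls gone and a chlorine present. Going by the values given here, no measured pair shows what happens when the ring is altered on a compound that already gives a low number, so the expectation is modest: an estimated step of a number 3.7 percentage points lower from compound 3 to compound 4 (within the scatter), small enough that it may fall within the scatter, since compound 3 already lies near the bottom of the numbers seen. Compound 4 is therefore expected to give about 12%, with a range from 3% to 30%.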

Compound 4, a percentage reported as inhibition, in the whole organism at one dose (the size of the read-out at that dose, not a potency): 68.3%
The estimate for compound 4 lay 56.3 percentage points below the measured number; measured number outside the range, above it.
By their numbers in this assay, from the lowest: compounds 2 and 3 (each within the scatter of the next); then compound 1; then compound 4.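

In this assay, the group on the amide-type nitrogen proves able to lift a low number a long way: 4-chlorophenyl in place of 2,5-dimethylphenyl gives a number 52.6 percentage points higher from compound 3 to compound 4 (beyond the scatter). Among the compounds shown here, the earlier steps showed only falls, both starting from compound 1, so this is the first sign that a compound carrying tert-butyl can still give a high number when this aryl group changes. Nothing at hand explains the rise.

The change removes both methyls and adds a chlorine in one move, so the compounds shown cannot separate these parts, and a plain phenyl or a 4-methoxyphenyl at this nitrogen could help to do so. From the compounds shown here alone, it also remains open whether 4-chlorophenyl would give a similar result with methyl in place of tert-butyl.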